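This account rests on a few compounds, and the source may have more. Where it says the series, first, only, none or still open, it means among the compounds named here.

Of the compounds shown here, three have so far been tested in an ADME assay on RD cells (Homo sapiens) for cytotoxicity, read by MTT assay, with a stated time of 24 h; a lower number here means that less compound is tolerated, a higher number that more compound is tolerated. Compound 1 `CC(CCOc1ccc(-c2noc(C(F)(F)F)n2)cc1)CCN1CCN(c2ccnc(N)c2)C1=O` gives 48100 nM. Compound 2 `CCO/N=C/c1ccc(OCCC(C)CCN2CCN(c3ccnc(OC)c3)C2=O)cc1` reaches only a limit of the assay, at > 100000 nM. Compound 3 `CCO/N=C/c1ccc(OCCC(C)CCN2CCN(c3cccc(N)c3)C2=O)cc1` likewise reaches only a limit, at > 100000 nM. The step that the two limits leave unreadable from compound 2 to compound 3 is unreadable because of the limit of > 100000 nM in this assay, at which 2 of the 3 values shown sit. Compound 3 thus stands at the limit of this assay, with no number of its own, alongside one other value that is also a limit.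

Compound 4 `CCO/N=C/c1ccc(OCCC(C)CCN2CCN(c3ccccc3)C2=O)cc1` differs from compound 3 in one place: hydrogen in place of amino on an aromatic carbon. Going by the values given here, no measured step removes an amino group in this way, and the only measured step that changes the group on the amide-type nitrogen in a ring is unreadable. Among the compounds with values here, the single numbered value, from compound 1, belongs to a different pairing and sets no direction. On this record the expected step from compound 3 to compound 4 in this assay is a number no higher from compound 3 to compound 4 (the limit leaves the size open), none beyond the scatter. Compound 4 is therefore estimated at 100000 nM, between 50000 nM and 200000 nM, most likely again reported only as a limit.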

Compound 4, half-maximal cytotoxic concentration: > 100000 nM
Compound 4: only a limit was reported; the forecaster's own chance of this, stated with the estimate: 70%; the middle value lies on the limit itself.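

No step can be read from compound 4 to compound 2 or compound 3, because all three stand at the same limit: the limit of > 100000 nM in this assay, at which 3 of the 4 values shown sit.

The compounds shown leave open how far apart these three truly lie, and whether removing the amino group changes tolerance at all.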